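A few compounds are considered here, and "the series" means these few. Any claim that something is new, unique, unknown or untested is made for them only; others in the source may bear on it.

In a functional assay on MCF7 cells (Homo sapiens) for inhibition, read by trypan blue exclusion, with a stated time of 72 h (on this read-out lower numbers stand for stronger inhibition of growth and higher numbers for weaker inhibition of growth), compound 3 `CC/C(=C(\c1ccccc1)c1ccc(NC(=O)C(C)C)cc1)c1ccc(O)cc1` gives 8100 nM and compound 2 `CC/C(=C(\c1ccc(NC(=O)C(C)C)cc1)c1ccc(OC)cc1)c1ccc(O)cc1` gives 9000 nM, two numbers that lie within the usual scatter of each other. Compound 1 `CC/C(=C(/c1ccccc1)c1ccc(NC(=O)C(C)C)cc1)c1ccc(OCc2ccccc2)cc1` is reported only as a limit of this assay, > 30000 nM. The next compound to test is compound 4 `CC/C(=C(/c1ccccc1)c1ccc(NC(=O)C(C)C)cc1)c1ccc(O)cc1`, which has the same atoms and bonds as compound 3: the two compounds have the same atoms and bonds and differ only in configuration as drawn: 1 of 1 stereo elements differ; a double bond is drawn Z in compound 3 and E in compound 4. Among the measured compounds shown here, the only change is in configuration, as a double bond is drawn Z in compound 3 and E in compound 4. For the measured compounds named here, no measured pair here shows what this kind of change does, so the expectation rests on the starting value of compound 3 at 8100 nM and remains uncertain. A change of shape alone could still matter, so the range is kept wide. No step beyond the scatter is expected in this assay, and the estimated 1.2-fold higher number from compound 3 to compound 4 (0.09 log units; within the scatter) is small. For compound 4 the expected value is 10000 nM, with an estimated range from 4000 nM to 25000 nM.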

Compound 4, concentration for 50% growth inhibition: 8500 nM
Beside the measured number, compound 4's estimate is 1.2-fold (0.07 log units) above it, and the stated range covers the measured number.
By their numbers in this assay, from the lowest: compounds 3, 4 and 2 (each within the scatter of the next). At a limit, above all of these: compound 1.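

In this assay, reversing the drawn geometry of the double bond gives a 1.0-fold higher number from compound 3 to compound 4 (0.02 log units; within the scatter), and this comparison isolates that one change: the fact that compounds 3 and 4 differ only in the configuration as drawn. Hydrogen in place of methoxy on an aromatic carbon likewise gives a 1.1-fold lower number from compound 2 to compound 4 (0.02 log units; within the scatter). Hydrogen in place of benzyl on an oxygen on an aromatic ring gives an at least 3.5-fold lower number from compound 1 to compound 4 (0.54 log units; beyond the scatter), the only step here beyond the scatter, and its true size stays unknown since compound 1 is reported only as a limit: the limit of > 30000 nM in this assay, at which 1 of the 4 values shown sits.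

The compounds shown leave open whether a smaller group on that oxygen, such as an ethyl or a longer chain, would stay close to the free hydroxyl or move toward the benzyl result. They also leave open what an amine in place of the amide would do.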